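A Shift of the Aryl Ether Substituent on a Thiazole Acid Core

The source may report more compounds than this note shows. Statements on the series, on what has been measured and on what is new or still open speak of the compounds shown alone.

Measured compounds:
compound 1 `O=C(O)c1csc([C@H]2CC[C@@H]3[C@@H](COc4ccc(OC(F)(F)F)cc4)[C@H](O)C[C@@H]3O2)n1` — 14 nM
compound 2 `Cc1ccc(OC[C@@H]2[C@H]3CC[C@H](c4nc(C(=O)O)cs4)O[C@H]3C[C@H]2O)cc1` — 27 nM

In a functional assay on CHO cells for agonist activity at prostaglandin E2 receptor EP2 subtype (Homo sapiens), read by HTRF and cAMP accumulation, with a stated time of 30 min (a higher number here means that more compound is needed for the effect, a lower number that less compound is needed), compound 1 gives 14 nM and compound 2 gives 27 nM. Compound 2 holds the higher of the two numbers, and its nearest neighbour is compound 1, reached through a 1.9-fold higher number from compound 1 to compound 2 (0.29 log units; within the scatter), a step that stays within the scatter. On these two numbers the two compounds cannot be ordered.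

Compound 3 `O=C(O)c1csc([C@H]2CC[C@@H]3[C@@H](COc4ccccc4C(F)(F)F)[C@H](O)C[C@@H]3O2)n1` differs from compound 2 in one place: 2-(trifluoromethyl)phenyl in place of 4-methylphenyl on an oxygen on a saturated carbon. Within the data shown here, only one measured step touches this part of the molecule, a 1.9-fold higher number from compound 1 to compound 2 (0.29 log units; within the scatter), and it exchanges groups of a different kind at a different position of the aryl ring, so it speaks to the new change only loosely. Among the measured compounds shown here, that step was small, and nothing among the measured compounds points to a large effect from the aryl substituent. The step from compound 2 to compound 3 is therefore expected to be a 1.1-fold higher number from compound 2 to compound 3 (0.05 log units; within the scatter), within the scatter. Compound 3 is estimated at 30 nM in this assay, with a range from 10 nM to 100 nM.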

Compound 3, half-maximal effective concentration: 0.5 nM
Compound 3: middle estimate off by 60-fold (1.78 log units), on the high side; the measured number lies below the stated range.
By their numbers in this assay, from the lowest: compound 3; then compounds 1 and 2 (each within the scatter of the next).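

In this assay, putting 2-(trifluoromethyl)phenyl in place of 4-methylphenyl on the oxygen gives a 54-fold lower number from compound 2 to compound 3 (1.73 log units; beyond the scatter). Among these compounds, the aryl group at this place can therefore shift the number far more than the one earlier step here suggested, since that step, a 1.9-fold higher number from compound 1 to compound 2 (0.29 log units; within the scatter), stayed within the scatter. The new step changes the substituent and its place on the ring together, so it cannot show which of the two carries the effect, and nothing measured on these compounds offers an explanation for its size.

On these data alone, it stays open whether a trifluoromethyl group would give a similar number in the place that the methyl holds in 4-methylphenyl, and whether a methyl group would do so in the place that the trifluoromethyl holds in 2-(trifluoromethyl)phenyl. As far as these compounds go, it is also open whether a chlorine atom or a methoxy group could stand in for the trifluoromethyl group in 2-(trifluoromethyl)phenyl and keep a number as low as that of compound 3 at 0.5 nM.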